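The source may report more compounds than this note shows. Statements on the series, on what has been measured and on what is new or still open speak of the compounds shown alone.

Measured so far in an assay on isolated protein for inhibition of 5-hydroxytryptamine receptor 4 (Homo sapiens); on this read-out higher numbers stand for weaker inhibition and lower numbers for stronger inhibition:
compound 1, `CS(=O)(=O)N1CCN(S(=O)(=O)CCCN2CCC(CNC(=O)c3cccc4c3OCCO4)CC2)CC1`: 0.316 nM
compound 2, `CCCS(=O)(=O)N1CCN(S(=O)(=O)CCCN2CCC(CNC(=O)c3cccc4c3OCCO4)CC2)CC1`: 0.1 nM

Compound 2 has the lower of the two numbers, separated from compound 1 by a 3.2-fold lower number from compound 1 to compound 2 (0.50 log units; beyond the scatter). Compound 3, `O=C(NCC1CCN(CCCS(=O)(=O)N2CCN(S(=O)(=O)c3ccc(F)cc3)CC2)CC1)c1cccc2c1OCCO2`, differs from compound 2 by 4-fluorophenyl in place of propyl on a sulfonyl sulfur, which the difference cut one bond further out reads as propylsulfonyl to (4-fluorophenyl)sulfonyl. Within the data shown here, the only measured step, the one from compound 1 to compound 2, enlarged the same group; a further enlargement is a different kind of change, so no step beyond the scatter is assumed. The expected step is a 1.5-fold higher number from compound 2 to compound 3 (0.18 log units; within the scatter). Compound 3 is therefore estimated at 0.15 nM, between 0.03 nM and 0.8 nM.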

Compound 3, inhibition constant: 0.0316 nM
For compound 3 the middle estimate is 4.7-fold (0.68 log units) above the measured one, and the stated range covers the measured number.
By their numbers in this assay, from the lowest: compound 3; then compound 2; then compound 1.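

Replacing propyl with 4-fluorophenyl on this sulfonyl sulfur gives a 3.2-fold lower number from compound 2 to compound 3 (0.50 log units; beyond the scatter) and shows that the position takes an aromatic ring as well as a saturated chain. Starting from methyl instead, the same group gives a 10-fold lower number from compound 1 to compound 3 (1.00 log units; beyond the scatter) and puts the three groups in one order, with the number falling from methyl to propyl to 4-fluorophenyl. No available evidence accounts for this order. As far as these compounds go, it remains open whether the ring or its fluorine matters more, a question that plain phenyl or 4-methoxyphenyl on the same sulfur would help to separate.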